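Shortening the Ether Chain of Compound 3

The source may hold more compounds than are shown below. What is called first, only, known or untested is meant among the compounds shown, and "the series" means these compounds.

In a functional assay on MV4-11 cells (Homo sapiens) for inhibition, read by resazurin assay, with a stated time of 72 h (a lower number here means a stronger inhibitor of growth, a higher number a weaker inhibitor of growth), compound 1 (`COc1ccc(Nc2nccc(-c3sc(SC)nc3C)n2)c(OC)c1`) gives 530 nM and compound 2 (`COc1ccc(Nc2nccc(-c3sc(SC(C)C)nc3C)n2)c(OC)c1`) gives 5670 nM while compound 3 (`COCCOc1nc(C)c(-c2ccnc(Nc3ccc(OC)cc3OC)n2)s1`) sits between them at 1980 nM on the scale. Compound 4 (`COc1ccc(Nc2nccc(-c3sc(OC)nc3C)n2)c(OC)c1`) has hydrogen in place of methoxymethyl on a saturated chain carbon bound to an oxygen on an aromatic ring so 2-methoxyethoxy becomes methoxy. Going by the values given here, no measured compound carries methoxy at this place. Two steps favour the smaller group: an 11-fold higher number from compound 1 to compound 2 (1.03 log units; beyond the scatter) with isopropyl in place of methyl on a sulfur, and a 3.7-fold higher number from compound 1 to compound 3 (0.57 log units; beyond the scatter) with 2-methoxyethoxy in place of methylsulfanyl. Compound 3 goes against a simple size rule, since a 2.9-fold lower number from compound 2 to compound 3 (0.46 log units; beyond the scatter) despite the longer chain. Methoxy resembles the methylsulfanyl of compound 1 at 530 nM more closely than 2-methoxyethoxy does. A modest fall is therefore expected, with an estimated 2.2-fold lower number from compound 3 to compound 4 (0.34 log units; beyond the scatter) as the size of the change. In this assay compound 4 is estimated at 900 nM with 350 nM to 2200 nM as its expected range.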

Compound 4, concentration for 50% growth inhibition: 1400 nM
The estimate for compound 4 lay 1.6-fold (0.19 log units) below the measured number; the range from low to high includes it.
By their numbers in this assay, from the lowest: compound 1; then compounds 4 and 3 (each within the scatter of the next); then compound 2.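

In this assay the shortening to methoxy gives a 1.4-fold lower number from compound 3 to compound 4 (0.15 log units; within the scatter) and so stays within the usual scatter, which means that losing the methoxymethyl leaves growth inhibition unchanged as far as this assay can tell. Methoxy can now be compared directly with both sulfur-bearing groups: a 2.6-fold higher number from compound 1 to compound 4 (0.42 log units; beyond the scatter) puts it behind methylsulfanyl, yet a 4.1-fold lower number from compound 2 to compound 4 (0.61 log units; beyond the scatter) puts it clearly ahead of isopropylsulfanyl, so having oxygen rather than sulfur at this place does not set the order by itself. Nothing given here explains these differences.

Still open is whether ethoxy, with a chain length not shown here, would behave like methoxy or fall away as isopropylsulfanyl does. An amine or a carboxylic acid at this place also remains untested among the compounds shown, so it is unknown whether any such group could outdo methylsulfanyl.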